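The source may report more compounds than this note shows. Statements on the series, on what has been measured and on what is new or still open speak of the compounds shown alone.

The three compounds measured so far, with their numbers:

compound 1, `Cc1c(C(=O)Nc2c(F)cc(-c3cccc(F)c3)cc2F)nc2ccc(F)cc2c1O`: 31.3%
compound 2, `Cc1ccc2nc(C(=O)Nc3c(F)cc(-c4cccc(F)c4)cc3F)c(C)c(C(=O)O)c2c1`: 35.6%
compound 3, `CCc1ccc2nc(C(=O)Nc3c(F)cc(-c4cccc(F)c4)cc3F)c(C)c(C(=O)O)c2c1`: 27.2%

All three were tested in a functional assay on Hep 3B2 cells (Homo sapiens) for antiproliferative activity, read by MTT assay, with a stated time of 24 h, tested at 11.11 ug/mL; a lower number here means a weaker effect, a higher number a stronger effect of the compound at the concentration tested. Compound 3 has the smallest of the three numbers, yet none of the three stands apart from the others: the step of a number 8.4 percentage points lower from compound 2 to compound 3 (within the scatter), and the gap between compound 1 and compound 3 is smaller still, so the three read as one level.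

Compound 4, `Cc1c(C(=O)Nc2c(F)cc(-c3cccc(F)c3)cc2F)nc2ccc(F)cc2c1C(=O)O`, is the next compound. It differs from compound 3 by fluoro in place of ethyl on an aromatic carbon.

Among the measured compounds shown here, only one measured step touches this place on the ring, the step of a number 8.4 percentage points lower from compound 2 to compound 3 (within the scatter), which swapped one small chain for another there without moving the number beyond the scatter. For the measured compounds named here, no measured step exchanges a chain for a fluoro at that place; compound 1 does carry a fluoro there but differs from compound 3 elsewhere as well, and its number sits within the scatter of compound 3 anyway. The expectation for this assay is therefore no step beyond the scatter, in either direction.

For compound 4 the estimated number is 30%, with a range from 18% to 42%, meaning an expected step of a number 2.8 percentage points higher from compound 3 to compound 4 (within the scatter).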

Compound 4, a percentage reported as inhibition, at one concentration (the size of the read-out at that concentration, not a potency): 26.3%
Estimate against measurement, compound 4: 3.7 percentage points above; the measured number falls inside the stated range.
By their numbers in this assay, from the lowest: compounds 4, 3, 1 and 2 (each within the scatter of the next).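

In this assay, putting fluoro in place of ethyl on this aromatic carbon gives a number 0.9 percentage points lower from compound 3 to compound 4 (within the scatter) and putting it in place of methyl gives a number 9.3 percentage points lower from compound 2 to compound 4 (within the scatter) for the same place on the ring. The earlier compounds shown here showed only one small chain exchanged for another here, whereas these steps show that a chain can give way to fluoro without the number leaving the scatter, so methyl, ethyl and fluoro all read as one level. Among the compounds shown here, compound 1 and compound 4 also form the first pair that differs only at a second place, and carboxy in place of hydroxy on an aromatic carbon gives a number 5 percentage points lower from compound 1 to compound 4 (within the scatter) with fluoro held constant, so this exchange does not separate the two compounds either.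

The compounds shown leave open whether a longer chain or an amine at the fluoro position would move the number beyond the scatter, and whether the level shared by all four compounds would hold at other concentrations, since each number comes from a single one. Nothing in the data shown gives a reason for this flat result.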